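Imine extension at the sulfonamide series

The source may hold more compounds than are shown below. What is called first, only, known or untested is meant among the compounds shown, and "the series" means these compounds.

Measured so far:
compound 1 `N#CC1=C(NC(=O)c2ccccc2)N(c2ccc(S(N)(=O)=O)cc2)C2=C(C(=O)CCC2)C1c1ccc(Cl)cc1Cl` — 60%
compound 2 `CN(C)c1ccc(/C=N/C2=C(C#N)C(c3ccc(Cl)cc3Cl)C3=C(CCCC3=O)N2c2ccc(S(N)(=O)=O)cc2)cc1` — 30%

In a functional assay on Ehrlich cells (Mus musculus) for cytotoxicity, read by trypan blue exclusion, with a stated time of 2 h, tested at 25 ug/mL (a higher number here means a stronger effect of the compound at the concentration tested, a lower number a weaker effect), compound 1 gives 60% and compound 2 gives 30%. Compound 2 thus stands lowest of the two numbers shown; its only neighbour is compound 1, from which it is reached by a number 30 percentage points lower from compound 1 to compound 2 (beyond the scatter).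

The next compound is compound 3 `CN(C)c1ccc(/C=C/C=N/C2=C(C#N)C(c3ccc(Cl)cc3Cl)C3=C(CCCC3=O)N2c2ccc(S(N)(=O)=O)cc2)cc1`. Its change from compound 2 is 2-(4-(dimethylamino)phenyl)ethenyl in place of 4-(dimethylamino)phenyl on a carbon with a double bond to nitrogen. The carbon carrying the double bond to nitrogen keeps its dimethylaminophenyl end, but that end now sits on an ethenyl bridge, one double bond outside aromatic rings being added.

For the measured compounds named here, no measured step bears directly on this change: the single step known, a number 30 percentage points lower from compound 1 to compound 2 (beyond the scatter), exchanges a different group on the shared core and says nothing about lengthening the imine substituent. With the measured numbers so sparse, the expectation is a step of a number 3 percentage points higher from compound 2 to compound 3 (within the scatter) that stays within the scatter, in no firm direction. Compound 3 is therefore estimated at 33%, with a range from 15% to 55%.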

Compound 3, a percentage reported as activity, at one concentration (the size of the read-out at that concentration, not a potency): 20%
For compound 3 the middle estimate is 13 percentage points above the measured one, and the stated range covers the measured number.
By their numbers in this assay, from the lowest: compounds 3 and 2 (each within the scatter of the next); then compound 1.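

In this assay, for the compounds shown here, placing 2-(4-(dimethylamino)phenyl)ethenyl in place of 4-(dimethylamino)phenyl on a carbon with a double bond to nitrogen gives a number 10 percentage points lower from compound 2 to compound 3 (within the scatter), the first reading of a change made within the imine substituent itself. The earlier step, a number 30 percentage points lower from compound 1 to compound 2 (beyond the scatter), exchanged the whole group on the double-bonded ring carbon, whereas this one keeps the imine and the dimethylaminophenyl end and adds only the ethenyl bridge, with its one double bond outside aromatic rings, and compound 2 and compound 3 cannot be told apart in this read-out. No measurement at hand offers an explanation for this outcome.

Still open, on these data alone, is whether the read-out at this carbon depends on the end group at all, which a plain phenyl, a methoxyphenyl or a hydroxyphenyl in place of the 4-(dimethylamino)phenyl end would test. Also open, as far as these compounds go, is whether a longer chain, with a second ethenyl unit in the bridge, would give a step beyond the scatter, since one added ethenyl bridge does not settle how the read-out follows the length of this substituent.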